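Fluorine on the Outer Ring in Two Matched Pairs

The source may report more compounds than this note shows. Statements on the series, on what has been measured and on what is new or still open speak of the compounds shown alone.

Of the compounds shown here, three have been measured so far in a functional assay on HeLa cells (Homo sapiens) for cytotoxicity, read by MTT assay, with a stated time of 2 days, tested at 1 uM; a higher number here means a weaker effect of the compound at the concentration tested, a lower number a stronger effect. Compound 1, `COc1ccc(-c2cc3cc(-c4ccccc4)cc(C(C)=O)c3[nH]2)cc1`, gives 61.5%. Compound 2, `COc1ccc(-c2cc3cc(-c4ccc(F)cc4)cc(C(C)=O)c3[nH]2)cc1`, differs from compound 1 by fluoro in place of hydrogen on an aromatic carbon, and in this assay compound 2 gives 62.9%. The step between the two is a number 1.4 percentage points higher from compound 1 to compound 2 (within the scatter), so the two numbers cannot be told apart. Compound 3, `CC(=O)c1cc(/C=C/c2ccccc2)cc2cc(-c3ccccc3)[nH]c12`, gives 79.8%, a number that stands beyond the scatter above both compound 1 and compound 2. How the core of compound 3 differs from the core of compound 1 is not broken down here; the two share no single counted difference.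

Compound 4, `CC(=O)c1cc(/C=C/c2ccc(F)cc2)cc2cc(-c3ccccc3)[nH]c12`, has not yet been measured in this assay. It differs from compound 3 by fluoro in place of hydrogen on an aromatic carbon, the same change that turns compound 1 into compound 2, and the place where the fluorine enters reads the same in both cases. Among the compounds shown, this change occurs only in these two pairs. For the measured compounds named here, the expectation for compound 4 rests on the single measured example, in which the change left the number for compound 1 and compound 2 within the scatter. On that basis the step from compound 3 is expected to be a number 1.2 percentage points higher from compound 3 to compound 4 (within the scatter). Compound 4 is therefore estimated to give about 81% in this assay, with the likely range running from 70% to 92%.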

Compound 4, a percentage reported as activity, at one concentration (the size of the read-out at that concentration, not a potency): 70%
For compound 4 the middle estimate is 11 percentage points above the measured one, and the stated range covers the measured number.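

On the core of compound 3, fluoro in place of hydrogen on an aromatic carbon gives a number 9.8 percentage points lower from compound 3 to compound 4 (within the scatter) in this assay, so this step, like the earlier one, cannot be told apart from no change at all. Set side by side, the two steps do not separate, and the change therefore carries from one core to the other without a difference that this assay can detect: the same change on two cores in this assay, a number 1.4 percentage points higher (within the scatter) from compound 1 to compound 2 and a number 9.8 percentage points lower (within the scatter) from compound 3 to compound 4, 11.2 percentage points apart, within the scatter of two such steps This shows only that on these two cores, where the fluorine enters para to a large group, the number stays within the scatter each time; it does not show that the two steps are equal, nor that a third core would behave the same way, and two pairs are too few to support a general rule for the series.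

Among the compounds shown, fluoro is the only group that takes the place of this hydrogen, so it remains open whether chloro, an amine or a carboxylic acid there would move the number in this assay beyond the scatter. Also open, going by these compounds, is how either pair would compare at other concentrations, as the read-out gives the size of the effect at one concentration and not a potency.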